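Oxetan-3-yl for methyl on the amino nitrogen

This account rests on a few compounds, and the source may have more. Where it says the series, first, only, none or still open, it means among the compounds named here.

Measured compounds:
Compound 1, `COc1nn(C)c2ncnc(NS(=O)(=O)c3cccc(Cl)c3Cl)c12`, gives 63.1 nM in a functional assay on cells for antagonist activity at C-C chemokine receptor type 4 (Homo sapiens), read by GTPgammaS binding; on this read-out lower numbers stand for stronger inhibition and higher numbers for weaker inhibition.
Compound 2, `COc1nn(CC(N)=O)c2ncnc(NS(=O)(=O)c3cccc(Cl)c3Cl)c12`, gives 501 nM in this assay.
Compound 3, `CNc1nc(NS(=O)(=O)c2cccc(Cl)c2Cl)c2c(OC)nn(C)c2n1`, gives 79.4 nM in this assay.

Compound 3 stands second among the three numbers; compound 1 is its nearest neighbour, and the gap between the two is within the scatter, so no order between them can be read. Compound 2 is the furthest from compound 3, and that gap lies beyond the scatter.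

Compound 4, `COc1nn(C)c2nc(NC3COC3)nc(NS(=O)(=O)c3cccc(Cl)c3Cl)c12`, is not yet measured. It differs from compound 3 in one place: oxetan-3-yl in place of methyl on a nitrogen on an aromatic ring.

For the measured compounds named here, none of the measured steps alters this nitrogen. The step of a 1.3-fold higher number from compound 1 to compound 3 (0.10 log units; within the scatter) shows that putting methylamino onto the core changed the number little, while a 7.9-fold higher number from compound 1 to compound 2 (0.90 log units; beyond the scatter) shows that enlarging a methyl elsewhere weakened inhibition. Going by the values given here, for the change in compound 4 no direct precedent exists, and a step close to the scatter is expected, with some chance of weakening: the expected step is a 1.3-fold higher number from compound 3 to compound 4 (0.10 log units; within the scatter). Compound 4 is therefore estimated at 100 nM, within the range 30 nM to 400 nM.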

Compound 4, half-maximal inhibitory concentration: 10000 nM
The estimate for compound 4 lay 100-fold (2.00 log units) below the measured number, and the stated range ends below it.
By their numbers in this assay, from the lowest: compounds 1 and 3 (each within the scatter of the next); then compound 2; then compound 4.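

In this assay, for the compounds shown here, the earlier compounds showed only that methylamino on the aromatic carbon left the number within the scatter of compound 1, and the nitrogen of that group now proves far from indifferent to what it carries: oxetan-3-yl in place of methyl gives a 130-fold higher number from compound 3 to compound 4 (2.10 log units; beyond the scatter). Set against the core with hydrogen at that carbon, (oxetan-3-yl)amino gives a 160-fold higher number from compound 1 to compound 4 (2.20 log units; beyond the scatter), so this position accepts methylamino but not this four-membered ring on the same nitrogen. Nothing available explains the loss.

The compounds shown leave open whether the loss follows the ring itself, its oxygen or simply the number of heavy atoms on the nitrogen. A cyclobutyl group or an ethyl group on this nitrogen would help to separate these readings.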